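Branched butyl variation on the carbonyl oxygen

A few compounds are considered here, and "the series" means these few. Any claim that something is new, unique, unknown or untested is made for them only; others in the source may bear on it.

compound 1 `CC1=C(C(=O)OCC(C)C)C(c2ccoc2)NC(=O)N1`: 326 nM
compound 2 `CC1=C(C(=O)OCC(C)C)C(c2cccs2)NC(=O)N1`: 2130 nM
compound 3 `CC1=C(C(=O)OC(C)C)[C@@H](c2ccco2)NC(=S)N1`: 6.3 nM

In an assay on membranes from HEK293 cells for displacement of a labelled ligand from adenosine receptor A2b (Homo sapiens), read by scintillation counting, with a stated time of 30 min (on this read-out lower numbers stand for stronger inhibition and higher numbers for weaker inhibition), compound 1 stands second highest of the three numbers. Its nearest neighbour is compound 2, reached by thiophen-2-yl in place of furan-3-yl on a saturated ring carbon, with a 6.5-fold higher number from compound 1 to compound 2 (0.82 log units; beyond the scatter). Compound 3 stands furthest away; it differs from compound 1 in several places at once, so only the two values themselves can be set side by side.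

Compound 4 `CCC(C)OC(=O)C1=C(C)NC(=O)NC1c1ccoc1` is not yet measured. It differs from compound 1 by sec-butyl in place of isobutyl on an oxygen next to a carbonyl group. Going by the values given here, no measured step touches the chain on the oxygen next to a carbonyl group, so nothing in the set speaks for a shift beyond the scatter. The estimated step is a 1.0-fold higher number from compound 1 to compound 4 (0.01 log units; within the scatter), i.e. none beyond the scatter. Compound 4 is estimated at 330 nM, range 110 nM to 1000 nM.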

Compound 4, inhibition constant: 201 nM
Estimate against measurement, compound 4: 1.6-fold (0.22 log units) above; measured number inside the range.
By their numbers in this assay, from the lowest: compound 3; then compounds 4 and 1 (each within the scatter of the next); then compound 2.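

In this assay, going by these compounds alone, sec-butyl in place of isobutyl gives a 1.6-fold lower number from compound 1 to compound 4 (0.21 log units; within the scatter) and is the first reading on the chain on the oxygen next to a carbonyl group. With the furan-3-yl group and the rest of the core held fixed, these two butyl groups cannot be told apart here. Nothing measured on these compounds offers an explanation for this result.

On these data alone, whether a straight butyl chain or a tert-butyl group at this place would also stay within the scatter remains open. So does whether the same exchange reads alike with thiophen-2-yl in place of furan-3-yl.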